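Compound 1 to compound 4: an aryl exchange

This account rests on a few compounds, and the source may have more. Where it says the series, first, only, none or still open, it means among the compounds named here.

compound 1 (`COc1cc(/C=C/C(=O)/C=C/c2cccc3ccccc23)ccc1OCc1cn(CCCOc2cc(=O)oc3ccccc23)nn1`): 71%
compound 2 (`COc1ccc(/C=C/C(=O)/C=C/c2ccc(OCc3cn(CCCCCOc4cc(=O)oc5ccccc45)nn3)c(OC)c2)cc1OC`): 47%
compound 3 (`COc1cc(/C=C/C(=O)/C=C/c2cccs2)ccc1OCc1cn(CCOc2cc(=O)oc3ccccc23)nn1`): 76%

All three values come from a functional assay on THP-1 cells (Homo sapiens) for inhibition, read by sulforhodamine B assay, with a stated time of 48 h, tested at 50 uM; a higher number here means more inhibition of growth at the concentration tested, a lower number less inhibition of growth. Compound 1 (71%) stands level with compound 3 within the scatter, while compound 2 lies lower, beyond the scatter.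

Compound 4 (`COc1cccc(/C=C/C(=O)/C=C/c2ccc(OCc3cn(CCCOc4cc(=O)oc5ccccc45)nn3)c(OC)c2)c1`) differs from compound 1 (3-methoxyphenyl in place of naphthalen-1-yl on a double-bonded chain carbon bound to a double-bonded chain carbon): 3-methoxyphenyl in place of naphthalen-1-yl on a double-bonded chain carbon bound to a double-bonded chain carbon. For the measured compounds named here, no measured pair shows this change alone. A small fall in this assay, within the scatter, is expected, the estimated step being (a number 8 percentage points lower from compound 1 to compound 4 (within the scatter)). For compound 4 the expected value is (63%), with an estimated range from (45%) to (79%).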

Compound 4, percent growth inhibition at one concentration: 58%
Beside the measured number, compound 4's estimate is 5 percentage points above it, and the stated range covers the measured number.
By their numbers in this assay, from the lowest: compound 2; then compound 4; then compounds 1 and 3 (each within the scatter of the next).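

In this assay, for the compounds shown here, this is the first single-place step: on a double-bonded chain carbon bound to a double-bonded chain carbon, 3-methoxyphenyl in place of naphthalen-1-yl gives a number 13 percentage points lower from compound 1 to compound 4 (beyond the scatter) and lies beyond the scatter. The aryl group at this position therefore affects growth inhibition, with the rest of the structure held constant. Nothing at hand explains this step.

Open, on these data alone, is whether the fall follows the lost second ring or the added methoxy group; phenyl and 3-aminophenyl would separate these. Compound 2 and compound 3 change chain and aryl group together, so chain length cannot be read alone.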